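Methoxy removal on the aniline-bearing ring of a thiazole series

This account rests on a few compounds, and the source may have more. Where it says the series, first, only, none or still open, it means among the compounds named here.

Of the compounds shown here, three have been measured in a functional assay on FM3A cells (Mus musculus) for inhibition, read by cell counting, with a stated time of 2 days; on this read-out lower numbers stand for stronger inhibition and higher numbers for weaker inhibition. Compound 1 `C=C(Br)C(=O)Nc1cccc(-c2cn3nc(-c4ccccc4)sc3n2)c1` gives 900 nM in this assay. Compound 3 `C=C(Br)C(=O)Nc1cccc(-c2cn3nc(-c4cccc(OC)c4)sc3n2)c1` gives 500 nM in this assay, and compound 2 `COc1ccc(-c2nn3cc(-c4cccc(N)c4)nc3s2)cc1OC` gives 13000 nM in this assay; compound 2 thus stands with the highest number of the three, beyond the scatter against both of the others. The difference between the core of compound 2 and the core of compound 3 is not broken down here.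

Compound 3 and compound 1 differ in one place, (hydrogen in place of methoxy on an aromatic carbon), and the step it made in this assay is a 1.8-fold higher number from compound 3 to compound 1 (0.26 log units; within the scatter).

Compound 4 `COc1ccc(-c2nn3cc(-c4cccc(N)c4)nc3s2)cc1` has not been measured. It differs from compound 2 in one place, (hydrogen in place of methoxy on an aromatic carbon). This is the same kind of change as that from compound 3 to compound 1, not the same: in compound 4 the place is ortho to a methoxy group and meta to a large group, whereas in compound 1 it is only meta to a large group.

Because the measured step of a 1.8-fold higher number from compound 3 to compound 1 (0.26 log units; within the scatter) lies within the scatter, a step of about the same size is expected here, a 1.5-fold higher number from compound 2 to compound 4 (0.19 log units; within the scatter), with wider uncertainty than usual given the different surroundings of the place. Compound 4 is estimated at 20000 nM in this assay, with a range from 8000 nM to 50000 nM.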

Compound 4, half-maximal inhibitory concentration: 74000 nM
The estimate for compound 4 lay 3.7-fold (0.57 log units) below the measured number; measured number outside the range, above it.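

Replacing methoxy with hydrogen does not carry over at one size between these cores in this assay: the same change on two cores in this assay, a 1.8-fold higher number (0.26 log units; within the scatter) from compound 3 to compound 1 and a 5.7-fold higher number (0.76 log units; beyond the scatter) from compound 2 to compound 4, 3.2-fold (0.50 log units) apart, beyond the scatter of two such steps

On the core of compound 2 the change gives a 5.7-fold higher number from compound 2 to compound 4 (0.76 log units; beyond the scatter), so at this place, ortho to a methoxy group and meta to a large group, the methoxy cannot be dropped without a measurable loss of inhibition, and the small step seen on the core of compound 1 is no safe guide to the size of the step elsewhere in the series. For the compounds shown here, what this does not show is the reason for the gap: the two pairs differ in their cores and also in the surroundings of the place, only two pairs are available, and nothing here separates these factors or supports a general rule for the series.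

From the compounds shown here alone, it remains open whether the step would grow on the core of compound 1 if the methoxy stood ortho to a second methoxy group, which would separate the effect of the surroundings from that of the core. Going by these compounds, it is also open how hydroxy, ethoxy or a fluorine atom at this place would compare with methoxy and hydrogen on either core.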